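Swapping an aromatic ring for a dihydropyran: solubility outlook

The source may hold more compounds than are shown below. What is called first, only, known or untested is meant among the compounds shown, and "the series" means these compounds.

Compound 1 `Cc1cc(NCc2ncccn2)n2nc(C)c(-c3ccccc3)c2n1`: 37900 nM
Compound 2 `Cc1cc(NCc2nccn2C)n2nc(C)c(-c3ccccc3)c2n1`: 26900 nM
Compound 3 `COc1ccc(-c2cnn3c(NCc4ccccn4)cc(C)nc23)cc1`: < 5000 nM

In a physicochemical assay for solubility, read by HPLC, using the shake flask method, measured as kinetic solubility, with a stated time of 2 h, at pH 7.4 (a lower number here means a less soluble compound, a higher number a more soluble compound), compound 1 gives 37900 nM and compound 2 gives 26900 nM, with a 1.4-fold lower number from compound 1 to compound 2 (0.15 log units; within the scatter). For compound 3 this assay reports only a limit, < 5000 nM, so its place among the measured compounds is known only as the lower edge (the limit of < 5000 nM in this assay, at which 1 of the 3 values shown sits). Compound 4 `Cc1cc(NCc2ccccn2)n2ncc(C3=CCOCC3)c2n1` has not yet been measured. It differs from compound 3 by a group of 6 heavy atoms (5 carbon, 1 oxygen; one six-membered non-aromatic ring with 1 hetero atom) in place of a group of 8 heavy atoms (7 carbon, 1 oxygen; one six-membered aromatic ring of carbon only), on an aromatic carbon. Among the compounds with values here, the single measured step concerns a different part of the molecule and does not bear on this change. Compound 4 is therefore expected to reach 20000 nM, within 5000 nM to 80000 nM, which would mean an estimated at least 4.0-fold higher number from compound 3 to compound 4 (0.60 log units; beyond the scatter).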

Compound 4, solubility: 171000 nM
Compound 4: the middle estimate sits 8.6-fold (0.93 log units) below what was measured; measured number outside the range, above it.
By their numbers in this assay, from the lowest: compounds 2 and 1 (each within the scatter of the next); then compound 4. At a limit, below all of these: compound 3.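

The earlier step changed only the group on the saturated chain carbon, and it stayed within the scatter. At the aromatic carbon of the five-membered ring, the six-membered non-aromatic ring in place of 4-methoxyphenyl gives an at least 34-fold higher number from compound 3 to compound 4 (1.53 log units; beyond the scatter) in this assay, the first change shown to go beyond the scatter. Compound 3 stands only at a limit, and the step is a floor for that reason: the limit of < 5000 nM in this assay, at which 1 of the 4 values shown sits.

As far as these compounds go, whether a saturated tetrahydropyran, a piperidine or a morpholine at this carbon would read alike stays open. So does whether the same exchange would hold with the pyrimidin-2-yl group of compound 1 on the chain.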